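The compounds below may be only part of what the source reports. "The series", "measured", "known", "first", "only" and "open" are said of these compounds alone.

Compound 1 `C=CCn1c(=O)/c(=C\c2cccc(C)c2)[nH]c(=O)/c1=C\c1ccccc1OC`: 20400 nM
Compound 2 `C=CCn1c(=O)/c(=C\c2cccc(F)c2)[nH]c(=O)/c1=C\c1ccccc1OC`: 5600 nM

In a functional assay on BGC-823 cells (Homo sapiens) for cytotoxicity, read by CCK-8 assay, with a stated time of 72 h (a lower number here means a stronger inhibitor, a higher number a weaker inhibitor), compound 2 stands at the lower of the two numbers, and the step of a 3.6-fold lower number from compound 1 to compound 2 (0.56 log units; beyond the scatter) places compound 1 apart from it beyond the scatter. Compound 3 `C=CCn1c(=O)/c(=C\c2cc(F)ccc2C)[nH]c(=O)/c1=C\c1ccccc1OC` has not yet been measured. Its difference from compound 2 is methyl in place of hydrogen on an aromatic carbon; cut one bond further out, the same difference reads 3-fluorophenyl to 5-fluoro-2-methylphenyl. Going by the values given here, the only measured step, a 3.6-fold lower number from compound 1 to compound 2 (0.56 log units; beyond the scatter), swapped one group for another at a single place while nothing was added; it does not show what a methyl entering beside a retained fluoro does. Among the compounds with values here, with no step of the same kind to lean on, a change in this assay within the scatter is expected, leaning toward a somewhat higher number. Compound 3 is therefore estimated at 7000 nM, between 2500 nM and 20000 nM. The expected step is a 1.3-fold higher number from compound 2 to compound 3 (0.10 log units; within the scatter).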

Compound 3, half-maximal inhibitory concentration: 1600 nM
Estimate against measurement, compound 3: 4.4-fold (0.64 log units) above, outside the stated range (below it).
By their numbers in this assay, from the lowest: compound 3; then compound 2; then compound 1.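

In this assay, a methyl on the aromatic carbon ortho to a large group and para to the fluoro group gives a 3.5-fold lower number from compound 2 to compound 3 (0.54 log units; beyond the scatter), which shows that this position accepts a methyl while the fluoro group is retained and that the number falls. Placing 5-fluoro-2-methylphenyl in place of 3-methylphenyl gives a 13-fold lower number from compound 1 to compound 3 (1.11 log units; beyond the scatter), the largest step among these compounds, so the ring carrying both groups stands beyond the scatter from each ring carrying only one. Nothing measured alongside these numbers offers an explanation for either step.

The compounds shown leave open whether the methyl would have the same effect without the fluoro group. They also leave open whether an ethyl, a methoxy group or an amine at this position would lower the number further.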